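The source may hold more compounds than are shown below. What is called first, only, known or untested is meant among the compounds shown, and "the series" means these compounds.

In a functional assay on SK-OV-3 cells (Homo sapiens) for antiproliferative activity, read by MTT assay, with a stated time of 72 h (a lower number here means a stronger inhibitor, a higher number a weaker inhibitor), compound 1 (`CC(C)(C)NC(=O)CCc1cccc2c1B(O)OC2`) gives > 100000 nM, which is a limit of the assay and not a number. Compound 2 (`O=C(CCc1cccc2c1B(O)OC2)Nc1nccs1`) gives > 100000 nM, again a limit and not a number, so its position is known only as the limit of > 100000 nM in this assay, at which 2 of the 2 values shown sit. Going by the values given here, the single measured step is a step that the two limits leave unreadable from compound 1 to compound 2. Compound 3 (`O=C(CCc1cccc2c1B(O)OC2)Nc1ccc(F)cc1`) keeps the shared core and the amide, and its change is 4-fluorophenyl in place of 1,3-thiazol-2-yl on an amide-type nitrogen, so 4-fluorophenyl replaces 1,3-thiazol-2-yl on the amide-type nitrogen. Since a step that the two limits leave unreadable from compound 1 to compound 2 offers no size to carry over, no direction can be drawn from it, and no change beyond the scatter is expected in this assay. The expected result is a number no higher from compound 2 to compound 3 (the limit leaves the size open). Compound 3 is estimated at 100000 nM, with an expected range from 40000 nM to 250000 nM, and the assay may well report only a limit again.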

Compound 3, half-maximal inhibitory concentration: 720 nM
Compound 3: middle estimate off by 140-fold (2.14 log units), on the high side, outside the stated range (below it).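

In this assay, the group on the amide-type nitrogen now proves able to move the result by a large margin, which the earlier pair could not show, as the step between them cannot be read. Putting 4-fluorophenyl in place of 1,3-thiazol-2-yl gives an at least 130-fold lower number from compound 2 to compound 3 (2.14 log units; beyond the scatter), and putting it in place of tert-butyl gives an at least 130-fold lower number from compound 1 to compound 3 (2.14 log units; beyond the scatter). Compound 3 alone gives a number, while compound 1 and compound 2 remain at a limit of the assay and not a number: the limit of > 100000 nM in this assay, at which 2 of the 3 values shown sit.

Still open, from the compounds shown here alone, is whether the gain belongs to the fluorine or to the six-membered carbon ring itself, which an unsubstituted phenyl on the same nitrogen would separate. Going by these compounds, how a 4-chlorophenyl or a 4-methoxyphenyl group would read there also remains unknown.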